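Benzyl for 2-Methoxyphenyl on an Amide Nitrogen

The source may hold more compounds than are shown below. What is called first, only, known or untested is meant among the compounds shown, and "the series" means these compounds.

Compound 1 `C=CC1=C(C(=O)NCc2ccccc2)C(c2ccc(OC)cc2)OC1`: > 100000 nM
Compound 2 `C=CC1=C(C(=O)Nc2ccccc2OC)C(c2ccc(Cl)c(Cl)c2)OC1`: > 100000 nM

In a functional assay on HeLa cells (Homo sapiens) for cytotoxicity, read by MTT assay, with a stated time of 24 h (a lower number here means a stronger inhibitor, a higher number a weaker inhibitor), compound 2 gives only a limit, > 100000 nM. Compound 1 likewise gives only a limit, > 100000 nM. Both measured compounds sit at the limit of > 100000 nM in this assay, at which 2 of the 2 values shown sit, so no numbered step exists between them. Compound 3 `C=CC1=C(C(=O)NCc2ccccc2)C(c2ccc(Cl)c(Cl)c2)OC1` differs from compound 2 by benzyl in place of 2-methoxyphenyl on an amide-type nitrogen. Compound 1 already carries the benzyl amide and reaches only a limit, > 100000 nM. The step from compound 2 to compound 3 is therefore expected to stay within scatter, a step that the limit leaves unreadable from compound 2 to compound 3. Compound 3 is expected at 150000 nM, between 50000 nM and 500000 nM, most likely again as a limit.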

Compound 3, half-maximal inhibitory concentration: > 100000 nM
Compound 3 was reported as a limit (the forecaster's own chance of this, stated with the estimate: 80%); the middle value lies beyond the limit too.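

No step can be read among compound 1, compound 2 and compound 3 in this assay, since each value is only a limit: the limit of > 100000 nM in this assay, at which 3 of the 3 values shown sit.
Going by these compounds, whether benzyl for 2-methoxyphenyl or 3,4-dichlorophenyl for 4-methoxyphenyl changes activity in this assay remains open.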